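Aryl group exchange at the aromatic nitrogen

A few compounds are considered here, and "the series" means these few. Any claim that something is new, unique, unknown or untested is made for them only; others in the source may bear on it.

Of the compounds shown here, two have been measured in a functional assay on Hep 3B2 cells (Homo sapiens) for inhibition, read by sulforhodamine B assay, with a stated time of 72 h, tested at 10 uM; a lower number here means less inhibition, a higher number more inhibition at the concentration tested (going by the name of the read-out). Compound 1 `C[C@H](Nc1nc(N)nc(N)c1C#N)c1nn(-c2cccc(S(C)(=O)=O)c2)c2cc(F)ccc12` gives 36%. Among the measured compounds shown here, compound 2 `C[C@H](Nc1ncnc2[nH]cnc12)c1nn(-c2cccc(F)c2)c2cc(F)ccc12` gives 28%; the two numbers lie within the usual scatter of one another, so compound 2 stands alongside compound 1 rather than apart from it, and no step between measured compounds is available as a guide. Compound 3 `C[C@H](Nc1ncnc2[nH]cnc12)c1nn(-c2ccc(C#N)cc2)c2cc(F)ccc12` is next to be measured. It differs from compound 2 in one place: 4-cyanophenyl in place of 3-fluorophenyl on an aromatic nitrogen. For the measured compounds named here, no measured pair shows the effect of such an exchange, so expectations rest on compound 2 alone. The change is expected to make little difference to compound 3, with a step of a number 2 percentage points higher from compound 2 to compound 3 (within the scatter) that lies within the scatter rather than beyond it in either direction. Compound 3 is therefore estimated at 30%, with a range from 10% to 55%.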

Compound 3, a percentage reported as inhibition, at one concentration (the size of the read-out at that concentration, not a potency): 46%
For compound 3 the middle estimate is 16 percentage points below the measured one; measured number inside the range.
By their numbers in this assay, from the lowest: compounds 2, 1 and 3 (each within the scatter of the next, the first and the last beyond it).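

Among the compounds shown here, the aryl group on the aromatic nitrogen is not a silent position in this assay: on an unchanged core, 4-cyanophenyl in place of 3-fluorophenyl gives a number 18 percentage points higher from compound 2 to compound 3 (beyond the scatter) as a modest step, the first readable step. The exchange changes both the group and its place on the phenyl ring, so the step cannot be assigned to the nitrile or to its placement alone. Compound 1 differs from compound 3 in more than one place and adds nothing to the reading of this exchange.

Still open, from the compounds shown here alone, is whether 3-cyanophenyl or 4-fluorophenyl would separate group from placement, and whether an amine or a carboxylic acid on the phenyl ring would keep the step. Nothing available bears on the reason for the step.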